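A few compounds are considered here, and "the series" means these few. Any claim that something is new, unique, unknown or untested is made for them only; others in the source may bear on it.

Values in an assay on isolated protein (Gallus gallus) for inhibition of transmembrane prolyl 4-hydroxylase (Homo sapiens); on this read-out lower numbers stand for stronger inhibition and higher numbers for weaker inhibition:

compound 1 `O=C(Nc1cccc(Cl)c1)c1ccc(C(=O)O)nc1`: 32200 nM
compound 2 `O=C(Nc1ccccc1F)c1ccc(C(=O)O)nc1`: 11000 nM
compound 3 `O=C(Nc1ccc(C(=O)O)nc1)c1ccccc1`: 25600 nM

Compound 3 stands second highest of the three numbers. Compound 1 lies nearest to it, and that gap is within the scatter, so the two are not told apart. Compound 2 gives the lower number, and that gap is beyond the scatter.

Compound 4 `CCOc1ccc(C(=O)Nc2ccc(C(=O)O)nc2)cc1` differs from compound 3 by ethoxy in place of hydrogen on an aromatic carbon. Among the measured compounds shown here, no step between measured compounds bears on this change, so its size cannot be read from the series. A modest move toward a lower number is expected, a 1.7-fold lower number from compound 3 to compound 4 (0.23 log units; within the scatter), well short of anything decisive. For compound 4 in this assay the estimate is 15000 nM, with a range from 5000 nM to 45000 nM.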

Compound 4, half-maximal inhibitory concentration: 11200 nM
The estimate for compound 4 lay 1.3-fold (0.13 log units) above the measured number, within the range that was stated.
By their numbers in this assay, from the lowest: compounds 2 and 4 (each within the scatter of the next); then compounds 3 and 1 (each within the scatter of the next).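

Ethoxy in place of hydrogen on an aromatic carbon, para to a large group, gives in this assay the first step that can be read in this series: a 2.3-fold lower number from compound 3 to compound 4 (0.36 log units; beyond the scatter) is modest but lies beyond the scatter. This position therefore accepts an ethoxy group without loss on this read-out, and the number moves toward stronger inhibition. Nothing available accounts for the step.

On these data alone, whether the oxygen or the ethyl chain carries the step remains open. Methoxy, a longer alkoxy chain, an ethyl group or an amine at this position could separate these.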